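A Shorter Spacer Before the Carbamate End

A few compounds are considered here, and "the series" means these few. Any claim that something is new, unique, unknown or untested is made for them only; others in the source may bear on it.

Of the compounds shown here, two have been measured so far in an assay on Flp-In-CHO cells for displacement of a labelled ligand from adenosine receptor A1 (Homo sapiens), read by radioligand binding; a higher number here means a weaker inhibitor, a lower number a stronger inhibitor. Compound 1 `CCCn1c(=O)c2[nH]c(C34CCC(C(=O)NCCNC(=O)CCNC(=O)CCNC(=O)CCCCC[N+]5=C(/C=C/C=C/C=C6/N(C)c7ccc(S(=O)(=O)O)cc7C6(C)C)C(C)(C)c6cc(S(=O)(=O)[O-])ccc65)(CC3)CC4)nc2n(CCC)c1=O` gives 200 nM in this assay. Among the compounds with values here, compound 2 `CCCn1c(=O)c2[nH]c(C34CCC(C(=O)NCCNC(=O)COCCOCCNC(=O)OC(C)(C)C)(CC3)CC4)nc2n(CCC)c1=O` gives 17.4 nM, the lowest of the two numbers, and its only neighbour, compound 1, stands beyond the scatter above it. Within the data shown here, no pair among the measured compounds differs in a single place, so no isolated step is available as a guide.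

Compound 3 `CCCn1c(=O)c2[nH]c(C34CCC(C(=O)NCCNC(=O)COCCNC(=O)OC(C)(C)C)(CC3)CC4)nc2n(CCC)c1=O` differs from compound 2 in one place: (tert-butoxycarbonyl)amino in place of 2-((tert-butoxycarbonyl)amino)ethoxy on a saturated chain carbon, two bonds along the chain from an oxygen on a saturated carbon. The change sits far out along the chain, away from the shared core, and removes part of the spacer while keeping the carbamate end. The step from compound 2 to compound 3 in this assay is expected to be small, a 1.0-fold higher number from compound 2 to compound 3 (0.01 log units; within the scatter), with no direction beyond the scatter. Compound 3 is therefore estimated at 18 nM, in a range from 7 nM to 45 nM.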

Compound 3, inhibition constant: 13.8 nM
The estimate for compound 3 lay 1.3-fold (0.12 log units) above the measured number, and the stated range covers the measured number.
By their numbers in this assay, from the lowest: compounds 3 and 2 (each within the scatter of the next); then compound 1.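

In this assay, within the data shown here, the first single-place step on this chain reads a 1.3-fold lower number from compound 2 to compound 3 (0.10 log units; within the scatter), so the spacer can lose part of its length without the number moving beyond the scatter. With the carbamate end kept, (tert-butoxycarbonyl)amino and 2-((tert-butoxycarbonyl)amino)ethoxy cannot be told apart at this place on a saturated chain carbon. Nothing available explains why the two compounds read alike.

From the compounds shown here alone, it remains open whether a still shorter or a longer chain would also stay within the scatter, and whether an amine or a carboxylic acid could take the place of the carbamate end. Compound 1 differs from compound 2 and compound 3 in more than one place, so its distance from them cannot be read as the effect of any single change.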